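Swapping the acyl chain on a trimethoxyphenyl amide

This account rests on a few compounds, and the source may have more. Where it says the series, first, only, none or still open, it means among the compounds named here.

Compound 1 `CCCCC(=O)N(Cc1ccc(OC)c(O)c1)c1cc(OC)c(OC)c(OC)c1`: 66 nM
Compound 2 `COc1ccc(CNc2cc(OC)c(OC)c(OC)c2)cc1Cl`: 46200 nM
Compound 3 `C/C=C/C(=O)N(Cc1ccc(OC)c(OC)c1)c1cc(OC)c(OC)c(OC)c1`: 20100 nM

Three compounds share a trimethoxyphenyl-bearing core and were tested in a functional assay on MGC-803 cells (Homo sapiens) for inhibition, read by MTT assay, with a stated time of 48 h; on this read-out higher numbers stand for weaker inhibition and lower numbers for stronger inhibition. Compound 1 gives the lowest number of the three, 66 nM, while compound 3 stands far higher at 20100 nM and compound 2 higher still at 46200 nM; both gaps lie well beyond the scatter, so compound 1 is the strongest inhibitor among them. Compound 4 `C=CC(=O)N(Cc1ccc(OC)c(O)c1)c1cc(OC)c(OC)c(OC)c1` has not yet been measured in this assay. It differs from compound 1 in one place: vinyl in place of butyl on a carbonyl carbon. Among the measured compounds shown here, no pair of measured compounds isolates this change. With compound 1 at 66 nM as the anchor, compound 4 is expected to come in somewhat weaker, a step of a 7.6-fold higher number from compound 1 to compound 4 (0.88 log units; beyond the scatter). Compound 4 is estimated at 500 nM, within a range from 80 nM to 3000 nM.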

Compound 4, half-maximal inhibitory concentration: 62 nM
For compound 4 the middle estimate is 8.1-fold (0.91 log units) above the measured one; measured number outside the range, below it.
By their numbers in this assay, from the lowest: compounds 4 and 1 (each within the scatter of the next); then compound 3; then compound 2.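

In this assay, vinyl in place of butyl on a carbonyl carbon gives a 1.1-fold lower number from compound 1 to compound 4 (0.03 log units; within the scatter), so the two compounds cannot be told apart. This pair shows that, at this place on the core of compound 1, the shorter vinyl and the longer butyl serve equally well in this read-out. Nothing measured here accounts for this match.

As far as these compounds go, whether a longer chain such as octyl, or an amine or a carboxylic acid at the end of the chain, would be accepted at this place remains open. So does the part played by the double bond, which ethyl in place of vinyl would test.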